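Ethyl to isopropyl on the sulfur of compound 3

The source may hold more compounds than are shown below. What is called first, only, known or untested is meant among the compounds shown, and "the series" means these compounds.

Measured so far in a functional assay on BJAB cells (Homo sapiens) for antiproliferative activity, with a stated time of 4 days; a higher number here means that more compound is needed for the effect, a lower number that less compound is needed:
compound 1 `CCSc1sc(-n2nc(C)c(Cc3ccccc3[N+](=O)[O-])c2C(=O)O)nc1-c1ccc(Cl)c(Cl)c1`: 59000 nM
compound 2 `Cc1oncc1-c1nc(-n2nc(C(=O)O)c(-c3cc(Cl)cc(Cl)c3)c2C)sc1SC(C)C`: > 44000 nM
compound 3 `CCSc1sc(-n2nc(C)c(Cc3ccccc3[N+](=O)[O-])c2C(=O)OC)nc1-c1ccc(Cl)c(Cl)c1`: 106000 nM

Compound 2 gives only a limit of the assay, (the limit of > 44000 nM in this assay, at which 1 of the 3 values shown sits), not a number. Of the two numbers, compound 3 lies within the scatter of compound 1: the step of a 1.8-fold higher number from compound 1 to compound 3 (0.25 log units; within the scatter) shows that the methyl ester in place of the acid changes little.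

Compound 4 `COC(=O)c1c(Cc2ccccc2[N+](=O)[O-])c(C)nn1-c1nc(-c2ccc(Cl)c(Cl)c2)c(SC(C)C)s1` differs from compound 3 by methyl in place of hydrogen on a saturated chain carbon bound to a saturated chain carbon and a sulfur. Among the compounds with values here, no measured step touches the sulfur chain; compound 2 carries the isopropylsulfanyl group but differs in several other places, so it cannot be read as a step. No change beyond the scatter is therefore expected in this assay : compound 4 is estimated at 100000 nM, between 45000 nM and 220000 nM, meaning an expected step of a 1.1-fold lower number from compound 3 to compound 4 (0.03 log units; within the scatter).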

Compound 4, half-maximal effective concentration: 93000 nM
Compound 4: the middle estimate sits 1.1-fold (0.03 log units) above what was measured; measured number inside the range.
By their numbers in this assay, from the lowest: compounds 1, 4 and 3 (each within the scatter of the next).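

In this assay, ethylsulfanyl to isopropylsulfanyl gives a 1.1-fold lower number from compound 3 to compound 4 (0.06 log units; within the scatter). Within the data shown here, until now, the only readable step concerned the ester and the acid; this one shows that adding a methyl on the saturated chain carbon bound to a sulfur also leaves the number within the scatter. Compound 2 carries isopropylsulfanyl too, but it differs in several other places and gives only a limit: the limit of > 44000 nM in this assay, at which 1 of the 4 values shown sits.

On these data alone, whether a longer chain, a cyclopentyl group or an amine on the sulfur would move the number beyond the scatter remains open. So does whether ethyl to isopropyl behaves alike when the carboxylic acid replaces the methyl ester.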